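The source may report more compounds than this note shows. Statements on the series, on what has been measured and on what is new or still open speak of the compounds shown alone.

The three measured compounds, all sharing one core and differing only in the group on the amide-type nitrogen:

Compound 1, `CCn1c(C(=O)NCCCN(C)C)ccc1C(CC)(CC)c1ccc(OCCC(O)(CC)CC)c(C)c1`, gives 2150 nM in a functional assay on PC-3 cells (Homo sapiens) for antiproliferative activity, read by MTT assay, with a stated time of 48 h; on this read-out higher numbers stand for weaker inhibition and lower numbers for stronger inhibition.
Compound 2, `CCn1c(C(=O)Nc2cccc(C(F)(F)F)c2)ccc1C(CC)(CC)c1ccc(OCCC(O)(CC)CC)c(C)c1`, gives 23800 nM in this assay.
Compound 3, `CCOc1ccc(NC(=O)c2ccc(C(CC)(CC)c3ccc(OCCC(O)(CC)CC)c(C)c3)n2CC)cc1`, reaches only a limit of this assay, > 50000 nM, and no number.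

Among the two real numbers, compound 2 has the higher one, and the nearest is compound 1, as the step of an 11-fold higher number from compound 1 to compound 2 (1.04 log units; beyond the scatter) shows. The remaining value, that of compound 3, is a limit (the limit of > 50000 nM in this assay, at which 1 of the 3 values shown sits).

Compound 4, `CCn1c(C(=O)NC(C)CO)ccc1C(CC)(CC)c1ccc(OCCC(O)(CC)CC)c(C)c1`, has not yet been measured. It differs from compound 2 in one place: 1-(hydroxymethyl)ethyl in place of 3-(trifluoromethyl)phenyl on an amide-type nitrogen.

Going by the values given here, two measured steps bear on this. Going from a chain bearing a basic amine to an aromatic ring, an 11-fold higher number from compound 1 to compound 2 (1.04 log units; beyond the scatter), raised the number sharply, and the second aromatic ring, an at least 23-fold higher number from compound 1 to compound 3 (1.36 log units; beyond the scatter), raised it at least as much. The change to compound 4 runs the other way, from an aromatic ring back to a short chain, though one carrying a hydroxyl instead of an amine. The number for compound 4 is therefore expected to fall below that of compound 2, by a step estimated as a 4.8-fold lower number from compound 2 to compound 4 (0.68 log units; beyond the scatter), without necessarily reaching compound 1. The estimate for compound 4 is 5000 nM, within 1500 nM to 15000 nM.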

Compound 4, half-maximal inhibitory concentration: 7870 nM
For compound 4 the middle estimate is 1.6-fold (0.20 log units) below the measured one, within the range that was stated.
By their numbers in this assay, from the lowest: compound 1; then compound 4; then compound 2. At a limit, above all of these: compound 3.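

In this assay, going by these compounds alone, the earlier compounds tied the only open chain, 3-(dimethylamino)propyl, to the lowest number, so the loss of the aromatic ring and the presence of the amine could not be told apart. Compound 4 carries an open chain with a hydroxyl and no amine, and it still improves on the 3-(trifluoromethyl)phenyl group, a 3.0-fold lower number from compound 2 to compound 4 (0.48 log units; beyond the scatter), yet it does not match the amine chain, a 3.7-fold higher number from compound 1 to compound 4 (0.56 log units; beyond the scatter), so within these compounds an open chain without the amine gives part of the gain, but not all of it. Against the 4-ethoxyphenyl group, the step is an at least 6.3-fold lower number from compound 3 to compound 4 (0.80 log units; beyond the scatter), and its size is only a bound, as compound 3 stands at a limit and not at a number: the limit of > 50000 nM in this assay, at which 1 of the 4 values shown sits.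

The 1-(hydroxymethyl)ethyl and 3-(dimethylamino)propyl groups differ in both chain and end group, so the compounds shown leave open how much of the remaining gap belongs to the amine and how much to the chain. A 3-hydroxypropyl group or a plain propyl group on this nitrogen would help to separate the two.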